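The compounds below may be only part of what the source reports. "The series", "measured", "known", "first", "only" and "open" are said of these compounds alone.

Of the compounds shown here, two have been measured in a physicochemical assay for lipophilicity, read by HPLC, measured as octanol-water partition; on this read-out lower numbers stand for lower lipophilicity and higher numbers for higher lipophilicity. Compound 1 `COC[C@H]1CN(c2ccc(-n3cc(-c4ccccn4)cn3)c(F)c2)C(=O)O1` gives 2.18 in this assay, and compound 2 `O=C1O[C@@H](Cn2ccnn2)CN1c1ccc(-n2cc(-c3ccccn3)cn2)c(F)c1` gives 2. Among the compounds with values here, the single step between them, a number 0.18 log units lower from compound 1 to compound 2 (within the scatter), shows that replacing the methoxy with the triazole ring on the chain carbon leaves this assay essentially unchanged. Compound 2 thus holds the lower of the two numbers, although its gap to compound 1 is within the scatter.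

Compound 3 `O=CNC[C@H]1CN(c2ccc(-n3cc(-c4ccccn4)cn3)c(F)c2)C(=O)O1` differs from compound 2 in one place: formylamino in place of 1H-1,2,3-triazol-1-yl on a saturated chain carbon bound to a saturated ring carbon. Within the data shown here, no measured step covers this exchange; the only step available, from a methoxy to the triazole, sits on the same position but concerns a different pair of groups, and it was within the scatter. The change removes an aromatic ring and brings in a hydrogen-bond donor, and from that a modest lowering of this assay is expected, a number 0.50 log units lower from compound 2 to compound 3 (beyond the scatter). Compound 3 is therefore estimated at 1.5, with a range from 1 to 2.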

Compound 3, partition coefficient: 1.19
Compound 3: the middle estimate sits 0.31 log units above what was measured; measured number inside the range.
By their numbers in this assay, from the lowest: compound 3; then compounds 2 and 1 (each within the scatter of the next).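

Up to this point, the saturated chain carbon bound to a saturated ring carbon had shown only a step within the scatter in this assay, so it could have seemed that the group placed there hardly mattered. Formylamino changes that reading, with a number 0.81 log units lower from compound 2 to compound 3 (beyond the scatter) and a number 0.99 log units lower from compound 1 to compound 3 (beyond the scatter) as the first steps at this place to lie beyond the scatter, which shows that the number in this assay does respond to the group at this position. Compared with 1H-1,2,3-triazol-1-yl, formylamino has no ring, fewer heavy atoms and fewer hydrogen-bond acceptors, and it adds a hydrogen-bond donor, but these differences all arrive together and no supporting measurement is available to tell which of them matters.

The compounds shown leave open whether the amide hydrogen of formylamino is what counts, a question that an N-methylformylamino or a methoxy-free acetylamino group at the same place could begin to separate. They also leave open how a primary amine, a carboxylic acid or a longer chain carrying the formylamino would read in this assay at this position.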